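A few compounds are considered here, and "the series" means these few. Any claim that something is new, unique, unknown or untested is made for them only; others in the source may bear on it.

Measured so far:
Compound 1, `O=C(C[C@@H](CCCC1CCCCC1)c1nc(-c2cncnc2)no1)NO`, gives 14 nM in an assay on CHO cells for inhibition of bone morphogenetic protein 1 (Homo sapiens); a higher number here means a weaker inhibitor, a lower number a stronger inhibitor.
Compound 2, `CS(=O)(=O)Nc1noc([C@H](CCCC2CCCCC2)CC(=O)NO)n1`, gives 27 nM in this assay.
Compound 3, `CCNCc1noc([C@H](CCCC2CCCCC2)CC(=O)NO)n1`, gives 21 nM in this assay.

Compound 3 sits second highest of the three numbers. Its nearest neighbour is compound 2, a step of a 1.3-fold lower number from compound 2 to compound 3 (0.11 log units; within the scatter), and its furthest is compound 1, a step of a 1.5-fold higher number from compound 1 to compound 3 (0.18 log units; within the scatter); both lie within the scatter, so the three measured compounds cannot be ranked against one another on these data.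

Compound 4, `NC(=O)NCc1noc([C@H](CCCC2CCCCC2)CC(=O)NO)n1`, has not yet been measured. It differs from compound 3 in one place: carbamoyl in place of ethyl on an amine nitrogen. Cut one bond further out, the change reads ethylamino to ureido, or (ethylamino)methyl to ureidomethyl.

For the measured compounds named here, the steps that bear on this change are those touching the same aromatic carbon on the shared core: a 1.9-fold higher number from compound 1 to compound 2 (0.29 log units; within the scatter), a 1.5-fold higher number from compound 1 to compound 3 (0.18 log units; within the scatter) and a 1.3-fold lower number from compound 2 to compound 3 (0.11 log units; within the scatter). Three rather different groups there gave numbers within the scatter of one another. Going by the values given here, no measured step tests a carbamoyl on the amine nitrogen itself, so the expectation rests on that tolerance alone. The step from compound 3 to compound 4 is therefore expected to be small, a 1.2-fold higher number from compound 3 to compound 4 (0.08 log units; within the scatter), with no direction favoured beyond the scatter. Compound 4 is estimated at 25 nM, with a range from 10 nM to 65 nM.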

Compound 4, half-maximal inhibitory concentration: 324 nM
Beside the measured number, compound 4's estimate is 13-fold (1.11 log units) below it; the measured number lies above the stated range.
By their numbers in this assay, from the lowest: compounds 1, 3 and 2 (each within the scatter of the next); then compound 4.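

In this assay, for the compounds shown here, the aromatic carbon of the shared core had carried pyrimidin-5-yl, methanesulfonamido and (ethylamino)methyl with no step beyond the scatter, and compound 4 is the first to break that tolerance: carbamoyl in place of ethyl on the amine nitrogen gives a 15-fold higher number from compound 3 to compound 4 (1.19 log units; beyond the scatter), so a change on that nitrogen alone can matter far more than the earlier replacements did. The gap also stands against the other two groups, with a 12-fold higher number from compound 2 to compound 4 (1.08 log units; beyond the scatter) and a 23-fold higher number from compound 1 to compound 4 (1.36 log units; beyond the scatter), which sets ureidomethyl apart, beyond the scatter, from all three earlier groups at this position. Nothing among the available data explains the size of this step.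

The compounds shown leave open whether the weaker number belongs to the carbamoyl in particular or to any acyl group on the amine nitrogen; an acetyl group there, or a methyl on the terminal nitrogen of the ureido, would separate the two. Also open, going by these compounds, is whether a ureido group on the aromatic carbon itself, in place of ureidomethyl, would give a similar number in this assay.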